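Two chalcone analogues with a shared trimethoxyphenyl pyrazole core

The compounds below may be only part of what the source reports. "The series", "measured", "known", "first", "only" and "open" are said of these compounds alone.

The study concerns compound 1 `COc1cc(-c2cc(/C=C/C(=O)c3ccc(Cl)c(Cl)c3)[nH]n2)cc(OC)c1OC` and compound 2 `COc1ccc(C(=O)/C=C/c2cc(-c3cc(OC)c(OC)c(OC)c3)n[nH]2)cc1OC`, which share one core and differ only in the aryl group on the carbonyl carbon. In a functional assay on SK-MEL-5 cells (Homo sapiens) for cytotoxicity, read by sulforhodamine B assay, with a stated time of 48 h, tested at 1 uM (on this read-out lower numbers stand for a stronger effect and higher numbers for a weaker effect at the one concentration tested), compound 1 gives 94%. In this assay compound 2 gives 91%, so that compound 2 and compound 1 stand within the usual scatter of one another, as the step of a number 3 percentage points lower from compound 1 to compound 2 (within the scatter) shows. Both numbers point to a weak effect at the single concentration tested.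

Compound 3 `COc1cc(-c2cc(/C=C/C(=O)c3ccc(F)c(F)c3)[nH]n2)cc(OC)c1OC` has not yet been measured. It differs from compound 2 as follows: 3,4-difluorophenyl in place of 3,4-dimethoxyphenyl on a carbonyl carbon. Among the measured compounds shown here, the only measured step that bears on this change is the one from compound 1 to compound 2, in which exchanging one 3,4-disubstituted phenyl on the carbonyl carbon for another moved the number by a number 3 percentage points lower from compound 1 to compound 2 (within the scatter). On that basis no step beyond the scatter is expected in this assay for compound 3, and the step of a number 2 percentage points higher from compound 2 to compound 3 (within the scatter) is the expected one. Compound 3 is therefore estimated to give 93%, in the range 82% to 102%.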

Compound 3, a percentage reported as activity, at one concentration (the size of the read-out at that concentration, not a potency): 90%
For compound 3 the middle estimate is 3 percentage points above the measured one; the measured number falls inside the stated range.
By their numbers in this assay, from the lowest: compounds 3, 2 and 1 (each within the scatter of the next).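

In this assay, a third aryl group on the carbonyl carbon again leaves the number where it was: 3,4-difluorophenyl gives a step of a number 1 percentage points lower from compound 2 to compound 3 (within the scatter) against 3,4-dimethoxyphenyl and a step of a number 4 percentage points lower from compound 1 to compound 3 (within the scatter) against 3,4-dichlorophenyl. Where the earlier pair compared only 3,4-dichlorophenyl with 3,4-dimethoxyphenyl, the new steps add an exchange of fluorine for chlorine and one in which a group with hydrogen-bond acceptors gives way to a group counted with none, and neither moves the number beyond the scatter at this position. The data give no measured property that could explain this insensitivity.

All three compounds carry a 3,4-disubstituted phenyl on the carbonyl carbon and all read as weak at the single concentration tested, so these results leave open whether a different kind of group at this place, such as a phenyl bearing an amine or a carboxylic acid, or a longer chain in place of the aryl ring, would shift the number beyond the scatter. They also leave open whether changes elsewhere on the shared core would do so.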